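The compounds below may be only part of what the source reports. "The series", "measured", "known", "first", "only" and "open" are said of these compounds alone.

Compound 1 `Clc1ccc(-c2nnc(COc3ccc(-c4ccccc4)cc3)o2)cc1` — 75%
Compound 2 `Clc1ccccc1-c1nnc(COc2ccc(-c3ccccc3)cc2)o1` — 59.1%
Compound 3 `COc1ccc2cc(C(C)c3nnc(COc4ccc(-c5ccccc5)cc4)o3)ccc2c1` — 25%

In a functional assay on the whole organism (strain Wistar) for inhibition, with Rattus norvegicus as the target, read by paw edema, with a stated time of 3 h, at a dose of 10 mg/kg by the oral route (a higher number here means more inhibition at the dose given (going by the name of the read-out), a lower number less inhibition), compound 2 gives 59.1%, the second highest of the three numbers. Compound 1 lies above it: a number 15.9 percentage points lower from compound 1 to compound 2 (beyond the scatter). Within the data shown here, compound 3 gives 25%, well under the value of compound 2; no single step links these two, so only their two values can be compared.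

Compound 4 `CCCCNc1nnc(COc2ccc(-c3ccccc3)cc2)o1` is not yet measured. It differs from compound 2 in one place: butylamino in place of 2-chlorophenyl on an aromatic carbon. Among the measured compounds shown here, the only measured step touching the same part of the shared core is a number 15.9 percentage points lower from compound 1 to compound 2 (beyond the scatter), which merely moved a chlorine within an aromatic ring and still cost a modest amount. Swapping the whole ring for a chain with a hydrogen-bond donor is a larger change with no direct precedent here, so the direction is uncertain, and a drop of moderate size seems the more likely outcome. Compound 4 is therefore estimated at 45%, within 25% to 65%, meaning an expected step of a number 14.1 percentage points lower from compound 2 to compound 4 (beyond the scatter).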

Compound 4, a percentage reported as inhibition, in the whole organism at one dose (the size of the read-out at that dose, not a potency): 15.9%
Compound 4: middle estimate off by 29.1 percentage points, on the high side; the measured number lies below the stated range.
By their numbers in this assay, from the lowest: compounds 4 and 3 (each within the scatter of the next); then compound 2; then compound 1.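

Among these compounds, until now, the only change at this carbon of the five-membered ring was moving the chlorine on the phenyl ring, which left the ring in place. In this assay, replacing the whole ring with the open butylamino chain gives a number 43.2 percentage points lower from compound 2 to compound 4 (beyond the scatter) and, starting from the 4-chlorophenyl group, a number 59.1 percentage points lower from compound 1 to compound 4 (beyond the scatter). Both steps are large, whereas moving the chlorine gave a modest one, and no other measurement is available that accounts for the drop.

Butylamino removes the aromatic ring and brings in a hydrogen-bond donor in a single change, so the compounds shown cannot separate those two differences. An anilino group, which keeps an aromatic ring on the same nitrogen, or a plain butyl chain, which has no nitrogen, would pull them apart.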